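The source may hold more compounds than are shown below. What is called first, only, known or untested is meant among the compounds shown, and "the series" means these compounds.

Working notes on the series.

Compound 1 `COc1ccc(/C=C/C(=O)/C=C/C2=C(C)CCCC2(C)C)cc1` and compound 2 `CC1=C(/C=C/C(=O)/C=C/c2ccc([N+](=O)[O-])cc2)C(C)(C)CCC1` share one core. In a functional assay on IMR-32 cells (Homo sapiens) for cytotoxicity, read by sulforhodamine B assay, with a stated time of 48 h (on this read-out lower numbers stand for stronger inhibition and higher numbers for weaker inhibition), compound 1 gives 23900 nM, and compound 2 gives 3200 nM. The change between them is nitro in place of methoxy on an aromatic carbon, and the step it made is a 7.5-fold lower number from compound 1 to compound 2 (0.87 log units; beyond the scatter).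

Compound 3 `COc1ccccc1/C=C/C(=O)/C=C/C1=C(C)CCCC1(C)C` carries the same atoms as compound 1, joined differently; the difference between the two cores is not broken down here. In this assay compound 3 gives 19200 nM, a value within the scatter of that of compound 1.

Compound 4 `CC1=C(/C=C/C(=O)/C=C/c2ccccc2[N+](=O)[O-])C(C)(C)CCC1` stands to compound 3 as compound 2 stands to compound 1: the change is nitro in place of methoxy on an aromatic carbon. The place lines differ: in the measured pair the group sits para to a large group, here it sits ortho to a large group, so this is the same kind of change, not the same.

For this assay the step from compound 3 to compound 4 is expected to be a 7.4-fold lower number from compound 3 to compound 4 (0.87 log units; beyond the scatter), resting on the size of a 7.5-fold lower number from compound 1 to compound 2 (0.87 log units; beyond the scatter), with added uncertainty from the changed place. Compound 4 is estimated at 2600 nM, between 1000 nM and 7000 nM.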

Compound 4, half-maximal inhibitory concentration: 13500 nM
Estimate against measurement, compound 4: 5.2-fold (0.72 log units) below; the measured number lies above the stated range.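

In this assay, nitro in place of methoxy gives a 1.4-fold lower number from compound 3 to compound 4 (0.15 log units; within the scatter), and the two steps for this change do not agree: the same change on two cores in this assay, a 7.5-fold lower number (0.87 log units; beyond the scatter) from compound 1 to compound 2 and a 1.4-fold lower number (0.15 log units; within the scatter) from compound 3 to compound 4, 5.3-fold (0.72 log units) apart, beyond the scatter of two such steps

The size of the step therefore does not carry from one pair to the other here, and a clear step on one core is a poor guide to the same change on the other. This does not show what sets the gap: the group sits para to a large group in one pair and ortho to a large group in the other, so the two cores and the two places cannot be told apart, and two pairs give no rule for the series.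

Open, as far as these compounds go, is how nitro and methoxy compare at any other place on the aromatic ring. Also open, from the compounds shown here alone, is whether other groups at these places, such as an amine or a carboxylic acid, follow the step of compound 1 to compound 2 or that of compound 3 to compound 4.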